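The source may report more compounds than this note shows. Statements on the series, on what has been measured and on what is new or still open speak of the compounds shown alone.

Compound 1 `Nc1cc(N)c2nc(-c3ccccc3)c(Oc3ccc(Cl)c(Cl)c3)nc2c1` is one of two measured members of this set. In a functional assay on DU-145 cells (Homo sapiens) for inhibition, read by sulforhodamine B assay, with a stated time of 48 h (on this read-out lower numbers stand for stronger inhibition of growth and higher numbers for weaker inhibition of growth), compound 1 returns only a limit of the assay, < 100000 nM. Compound 2 `CCOC(=O)[C@H](CCC(=O)O)NC(=O)c1ccc(Sc2nc3cc(N)cc(N)c3nc2-c2ccccc2)cc1` likewise stops at a limit in this assay, < 100000 nM, so that (the limit of < 100000 nM in this assay, at which 2 of the 2 values shown sit). Compound 3 `Nc1cc(N)c2nc(-c3ccccc3)c(Sc3ccc(F)cc3)nc2c1` carries (4-fluorophenyl)sulfanyl in place of 3,4-dichlorophenoxy on an aromatic carbon. No step between measured compounds is available, and the size of the change from compound 1 to compound 3 cannot be read from the numbers shown. Compound 3 is expected to sit near the same limit, estimated at 80000 nM with a range of 25000 nM to 250000 nM, with the step that the limit leaves unreadable from compound 1 to compound 3 expected to be none beyond the scatter.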

Compound 3, concentration for total growth inhibition: < 100000 nM
Compound 3: only a limit was reported (the forecaster's own chance of this, stated with the estimate: 70%); the middle value lies beyond the limit too.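

Going by these compounds alone, compound 1 and compound 3 both stop at a limit of the assay, and no step between them can be read. Left open is how strongly each compound shown acts in this assay and whether (4-fluorophenyl)sulfanyl in place of 3,4-dichlorophenoxy changes that.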